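The source may hold more compounds than are shown below. What is called first, only, known or untested is meant among the compounds shown, and "the series" means these compounds.

Measured so far:
- Compound 1 `COC(=O)Nc1sc2c(c1C(=O)Nc1ccc(OC)cc1)CCCCC2`: > 50000 nM
- Compound 2 `O=C(Nc1ccc(Cl)cc1)c1c(NC(=O)C(F)(F)F)sc2c1CCCCC2`: > 50000 nM

Among the measured compounds shown here, only two compounds have been measured in an ADME assay on THP-1 cells (Homo sapiens) for cytotoxicity (a higher number here means that more compound is tolerated, a lower number that less compound is tolerated), and neither has yielded a number. Compound 1 gives > 50000 nM, which is a limit of the assay and not a number. Compound 2 gives > 50000 nM, which is likewise a limit. Compound 1 therefore stands with compound 2, and the record reads (the limit of > 50000 nM in this assay, at which 2 of the 2 values shown sit).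

Compound 3 `COc1ccc(NC(=O)c2c(NC(C)=O)sc3c2CCCCC3)cc1` has not yet been measured. It departs from compound 1 in one place: methyl in place of methoxy on a carbonyl carbon. For the measured compounds named here, no measured step shows what this change does. With both values in this assay at the limit, the expected step of a number no higher from compound 1 to compound 3 (the limit leaves the size open) is none beyond the scatter, and a limit is again the likely result. For compound 3 the estimated value is 50000 nM, with an expected range from 25000 nM to 100000 nM.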

Compound 3, half-maximal cytotoxic concentration: > 50000 nM
Compound 3: only a limit was reported; the forecaster's own chance of this, stated with the estimate: 85%; the middle value sits exactly at the limit.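

In this assay compound 3 gives > 50000 nM, which is a limit and not a number. Compound 1 also stands at a limit, so the step from compound 1 to compound 3 cannot be read. The compounds shown leave open which change, if any, would yield a measurable value: the limit of > 50000 nM in this assay, at which 3 of the 3 values shown sit.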